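A few compounds are considered here, and "the series" means these few. Any claim that something is new, unique, unknown or untested is made for them only; others in the source may bear on it.

Compound 3 `COc1ccc2[nH]c3c(c2c1)CCNC31CCN(Cc2ccc(F)cc2F)CC1` gives 2000 nM in an assay on FRT cells for positive allosteric modulation of Cystic fibrosis transmembrane conductance regulator variant N1303K (Homo sapiens), in the presence of a further agent that is not named here; on this read-out lower numbers stand for an effect already at smaller amounts and higher numbers for an effect only at larger amounts of compound. Compound 2 `COc1ccc2[nH]c3c(c2c1)CCNC31CCN(Cc2cc(F)cc(Cl)c2)CC1` gives 2500 nM, and the two sit within the scatter of each other, a 1.3-fold lower number from compound 2 to compound 3 (0.10 log units; within the scatter). Compound 1 `COc1ccc2[nH]c3c(c2c1)CCNC31CCN(Cc2ccccc2)CC1` gives 12600 nM, a number clearly apart, a 6.3-fold lower number from compound 1 to compound 3 (0.80 log units; beyond the scatter). Compound 4 `COc1ccc2[nH]c3c(c2c1)CCNC31CCN(Cc2ccco2)CC1` differs from compound 3 in one place: furan-2-yl in place of 2,4-difluorophenyl on a saturated chain carbon bound to an amine nitrogen in a ring. Among the compounds with values here, no measured step exchanges a six-membered ring for a five-membered one, so the only guidance comes from the steps that add halogens to phenyl, a 5.0-fold lower number from compound 1 to compound 2 (0.70 log units; beyond the scatter) and a 6.3-fold lower number from compound 1 to compound 3 (0.80 log units; beyond the scatter), both modest. Furan-2-yl carries no halogen, so a modest rise toward compound 1 is expected; compound 4 is estimated at 7000 nM, with a likely range from 2500 nM to 20000 nM, a step of a 3.5-fold higher number from compound 3 to compound 4 (0.54 log units; beyond the scatter).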

Compound 4, half-maximal effective concentration: 16400 nM
Compound 4: the middle estimate sits 2.3-fold (0.37 log units) below what was measured, and the stated range covers the measured number.
By their numbers in this assay, from the lowest: compounds 3 and 2 (each within the scatter of the next); then compounds 1 and 4 (each within the scatter of the next).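

In this assay, furan-2-yl on this saturated chain carbon lands level with plain phenyl, a 1.3-fold higher number from compound 1 to compound 4 (0.11 log units; within the scatter), so this five-membered ring with its oxygen shows no separation from the unsubstituted six-membered ring. Both halogen-bearing phenyl rings stay clearly ahead of it, an 8.2-fold higher number from compound 3 to compound 4 (0.91 log units; beyond the scatter) and a 6.6-fold higher number from compound 2 to compound 4 (0.82 log units; beyond the scatter). No measurement here explains this pattern. Still open, from the compounds shown here alone, is whether a chlorine on the furan ring would bring a gain like that seen on phenyl, and whether a thiophene or pyridine ring would behave like furan-2-yl.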